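The source may hold more compounds than are shown below. What is called first, only, known or untested is meant among the compounds shown, and "the series" means these compounds.

Three compounds share one core: compound 2 `O=S(=O)(NCCCNCc1ccc(C(F)(F)F)cc1)c1cc(C(F)(F)F)cc(C(F)(F)F)c1`, compound 3 `O=S(=O)(NCCCNCc1ccc(-c2ccccc2)cc1)c1cc(C(F)(F)F)cc(C(F)(F)F)c1` and compound 1 `O=S(=O)(NCCCCNCc1ccc(Br)cc1)c1cc(C(F)(F)F)cc(C(F)(F)F)c1`. In a functional assay on MIA PaCa-2 cells (Homo sapiens) for inhibition, read by MTT assay, with a stated time of 72 h (on this read-out lower numbers stand for stronger inhibition of growth and higher numbers for weaker inhibition of growth), compound 2 gives 2500 nM, compound 3 gives 2400 nM and compound 1 gives 2100 nM; all three numbers lie within the scatter of one another, so compound 2 stands level with the others rather than apart from them.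

Compound 4 `O=S(=O)(NCCCNCc1cccc(Cl)c1)c1cc(C(F)(F)F)cc(C(F)(F)F)c1` is compound 2 with one change: 3-chlorophenyl in place of 4-(trifluoromethyl)phenyl on a saturated chain carbon bound to an amine nitrogen. Among the compounds with values here, only one measured step touches the same position, a 1.0-fold lower number from compound 2 to compound 3 (0.02 log units; within the scatter), and it made no difference beyond the scatter. Compound 1, with a different chain length and a bromine, differs from compound 2 in more than one place, and its value also sits within the scatter of compound 2. Nothing measured here points to a large shift from exchanging the group on the benzyl carbon, so the expected step in this assay, a 1.0-fold lower number from compound 2 to compound 4 (0.02 log units; within the scatter), is none beyond the scatter. Compound 4 is therefore estimated at 2400 nM in this assay, with a range from 1200 nM to 5000 nM.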

Compound 4, concentration for 50% growth inhibition: 4400 nM
Compound 4: the middle estimate sits 1.8-fold (0.26 log units) below what was measured; low and high end bracket the measured number.
By their numbers in this assay, from the lowest: compounds 1, 3, 2 and 4 (each within the scatter of the next, the first and the last beyond it).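

In this assay the change from 4-(trifluoromethyl)benzyl to 3-chlorobenzyl gives a 1.8-fold higher number from compound 2 to compound 4 (0.25 log units; within the scatter), so this position has now taken a second kind of exchange without a step beyond the scatter. Within the data shown here, the one step here that passes the scatter is a 2.1-fold higher number from compound 1 to compound 4 (0.32 log units; beyond the scatter), and it is modest; the chain and the ring group change together in it, so the share of each cannot be separated. No measurement shown gives a reason for either step.

As far as these compounds go, it remains open whether an amine or a carboxylic acid on the benzyl ring would move the number further than the groups seen so far. From the compounds shown here alone, it is also open how a longer chain would act with the 3-chlorobenzyl group kept in place.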